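The source may hold more compounds than are shown below. What is called first, only, known or untested is meant among the compounds shown, and "the series" means these compounds.

Measured compounds:
Compound 1, `C[Si](C)(C)c1ccc2nc(N)sc2c1`: 5 mg/kg
Compound 2, `N#CCn1c(=N)sc2cc(OC(F)(F)F)ccc21`: 3.5 mg/kg

In a functional assay on the whole organism with Rattus norvegicus as the target (on this read-out higher numbers stand for an effect only at larger amounts of compound and lower numbers for an effect already at smaller amounts), compound 1 gives 5 mg/kg, and in this assay compound 2 gives 3.5 mg/kg. The two numbers lie within the scatter of each other, so neither compound can be set apart from the other on these data; the number of compound 2 is the lower of the two, but only by a gap that repeated measurements of this kind would not resolve.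

Compound 3, `CNCCn1c(=N)sc2cc(OC(F)(F)F)ccc21`, has not yet been measured. It differs from compound 2 as follows: (methylamino)methyl in place of cyano on a saturated chain carbon bound to an aromatic nitrogen. No pair of measured compounds shows a step of this kind, so the expectation for compound 3 rests only on the two numbers shown and on the change itself. The step of a 1.4-fold higher number from compound 2 to compound 3 (0.15 log units; within the scatter) is expected to be small, at most a modest move toward a higher number, and possibly none beyond the scatter. Compound 3 is therefore expected to give 5 mg/kg, with a range from 1.5 mg/kg to 15 mg/kg.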

Compound 3, dose for half-maximal effect: > 10 mg/kg
Compound 3 gave a limit, no number; the forecaster's own chance of this, stated with the estimate: 10%; middle value at least 2.0-fold (0.30 log units) away from the limit.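

Replacing cyano with (methylamino)methyl on a saturated chain carbon bound to an aromatic nitrogen is not a neutral change in this assay: it gives an at least 2.8-fold higher number from compound 2 to compound 3 (0.45 log units; beyond the scatter). The earlier compounds shown here could not show this, as no step at this position was available, and the pair now shows that the read-out responds to what this position carries. The value for compound 3 is a limit and not a number, so only the lower end of the step can be read: the limit of > 10 mg/kg in this assay, at which 1 of the 3 values shown sits.

The compounds shown do not separate the loss of the nitrile from the gain of the methylamino end, as cyanomethyl gives way to 2-(methylamino)ethyl in a single change. A plain propyl chain, a primary amine or a dimethylamino group at this place, or a carboxylic acid, would each bear on that question.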